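The source may report more compounds than this note shows. Statements on the series, on what has been measured and on what is new or still open speak of the compounds shown alone.

In a functional assay on HL-60 cells (Homo sapiens) for antiproliferative activity, read by MTT assay (on this read-out higher numbers stand for weaker inhibition and lower numbers for stronger inhibition), compound 1 `O[C@@H]1[C@@H](OCc2ccccc2)[C@H](OCc2ccccc2)[C@@H](COCc2ccccc2)O[C@H]1CC1CCCCC1` gives 4100 nM, while compound 2 `CCC[C@@H]1O[C@H](COCc2ccccc2)[C@@H](OCc2ccccc2)[C@H](OCc2ccccc2)[C@H]1O` gives 11700 nM, the higher of the two numbers. Compound 3 `CC(C)(C)C[C@@H]1O[C@H](COCc2ccccc2)[C@@H](OCc2ccccc2)[C@H](OCc2ccccc2)[C@H]1O` keeps the shared core but carries tert-butyl in place of ethyl on a saturated chain carbon bound to a saturated ring carbon. Going by the values given here, only one measured step bears on this change, and it falls at the same place: a 2.9-fold higher number from compound 1 to compound 2 (0.46 log units; beyond the scatter), modest but beyond the scatter, with ethyl in place of cyclohexyl. Read in reverse, that step pairs cyclohexyl with the lower number, so tert-butyl may also lower it, though a single step establishes no pattern. Among the compounds with values here, a modest move toward a lower number in this assay is therefore expected, no larger than that step: a 2.0-fold lower number from compound 2 to compound 3 (0.29 log units; within the scatter). Compound 3 is estimated at 6000 nM, within a range from 2500 nM to 13000 nM.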

Compound 3, half-maximal inhibitory concentration: "not active" (no number reported)
Compound 3: no number reported; the estimate stays without a comparison.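

Going by these compounds alone, compound 3 is reported as not active in this assay without a number, and no step from compound 2 to compound 3 can be read. The compounds shown leave open how far tert-butyl stands from ethyl or cyclohexyl at this place. No supporting evidence bears on this result.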